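This account rests on a few compounds, and the source may have more. Where it says the series, first, only, none or still open, it means among the compounds named here.

Measured so far in a physicochemical assay for solubility, read by HPLC, at pH 7.4; a lower number here means a less soluble compound, a higher number a more soluble compound:
compound 1, `CCCCC#Cc1c(C)[nH]c2ccc(Cl)cc2c1=O`, gives 2000 nM.
compound 2, `CCCCC#Cc1c(C)[nH]c2ccc(F)cc2c1=O`, gives 2000 nM.
compound 3, `CCc1c(C)[nH]c2cc(OC)c(F)cc2c1=O`, gives only a limit of the assay, < 2000 nM.

Compound 1 and compound 2 share a core; how the core of compound 3 differs from that of compound 2 is not broken down here. Between compound 2 and compound 1 the change is chloro in place of fluoro on an aromatic carbon, and in this assay the step is no change at the digits printed from compound 2 to compound 1 (within the scatter).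

Compound 4, `CCc1c(C)[nH]c2cc(OC)c(Cl)cc2c1=O`, is not yet measured. From compound 3 it differs by chloro in place of fluoro on an aromatic carbon. This is the same kind of change as from compound 2 to compound 1, not the same: in compound 4 the changed carbon is ortho to a methoxy group, which is absent around the changed carbon of compound 1.

Resting on the flat step no change at the digits printed from compound 2 to compound 1 (within the scatter), the step expected in this assay is a step that the limit leaves unreadable from compound 3 to compound 4. Because compound 3 sits at the limit (the limit of < 2000 nM in this assay, at which 1 of the 3 values shown sits), compound 4 may likewise be reported only as a limit. The estimate for compound 4 in this assay is 1500 nM, with a range from 400 nM to 4000 nM.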

Compound 4, solubility: 10000 nM
Beside the measured number, compound 4's estimate is 6.7-fold (0.82 log units) below it; measured number outside the range, above it.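

In this assay, chloro in place of fluoro on an aromatic carbon does not read the same on the two cores: on one the step is no change at the digits printed from compound 2 to compound 1 (within the scatter) and on the other it is an at least 5.0-fold higher number from compound 3 to compound 4 (0.69 log units; beyond the scatter) on a carbon ortho to a methoxy group. That second step has a floor and no measured size because compound 3 is reported only as a limit: the limit of < 2000 nM in this assay, at which 1 of the 4 values shown sits. The two cores differ in more than one place, so these two pairs show that the flat result on the first core does not transfer, but they do not show which difference between the cores goes with the divergence.

Going by these compounds alone, with only two pairs, it remains open how the same change reads on any further core, or with the methoxy group moved or replaced. From the compounds shown here alone, it is also open whether the result for compound 4 holds when an amine or a carboxylic acid is carried on the same core.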